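This account rests on a few compounds, and the source may have more. Where it says the series, first, only, none or still open, it means among the compounds named here.

Of the compounds shown here, three have numbers so far. In a functional assay on K562 cells (Homo sapiens) for cytotoxicity, read by XTT assay, with a stated time of 24 h (on this read-out higher numbers stand for weaker inhibition and lower numbers for stronger inhibition), compound 1 (`Cc1ccc(NC(=O)c2ccc(Br)cc2OCCCCn2ccnc2)cc1Nc1nccc(-c2cccnc2)n1`) gives 66100 nM and compound 3 (`Cc1ccc(NC(=O)c2ccc(OCCCCn3ccnc3)cc2)cc1Nc1nccc(-c2cccnc2)n1`) gives 49900 nM, so these two sit within the scatter of each other. Compound 2 (`COc1ccc(C(=O)Nc2ccc(C)c(Nc3nccc(-c4cccnc4)n3)c2)cc1OCCCCn1ccnc1`) gives 10100 nM, a lower number than that of compound 1 and one beyond the scatter. Compound 1 thus stands at the weak end of this small set, level with compound 3.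

The next compound to be read is compound 4 (`Cc1ccc(NC(=O)c2ccc(I)cc2OCCCCn2ccnc2)cc1Nc1nccc(-c2cccnc2)n1`). It has iodo in place of bromo on an aromatic carbon, meta to a 4-(1H-imidazol-1-yl)butoxy group and para to a large group: iodo in place of bromo on an aromatic carbon. Among the measured compounds shown here, the series holds no measured pair differing in one place, so this swap has no direct precedent. No step beyond the scatter is expected in this assay, in either direction. The estimated step is a 1.1-fold lower number from compound 1 to compound 4 (0.04 log units; within the scatter). For compound 4 the estimated value is 60000 nM, with an expected range of 25000 nM to 130000 nM.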

Compound 4, half-maximal inhibitory concentration: 57400 nM
Estimate against measurement, compound 4: 1.0-fold (0.02 log units) above; the range from low to high includes it.
By their numbers in this assay, from the lowest: compound 2; then compounds 3, 4 and 1 (each within the scatter of the next).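

In this assay, among the compounds shown here, the swap of iodo for bromo on an aromatic carbon, meta to a 4-(1H-imidazol-1-yl)butoxy group and para to a large group, gives the first step between compounds that differ in one place: a 1.2-fold lower number from compound 1 to compound 4 (0.06 log units; within the scatter). This step lies within the scatter, so this position accepts either halogen without a change that this read-out can resolve. No measurement offered here explains this outcome.

As far as these compounds go, two halogens say little about the position as a whole, and whether a smaller chloro or fluoro, or a different kind of group such as a nitrile, an amine or a carboxylic acid, would hold the read-out at this level remains open. Also open, from the compounds shown here alone, is whether any change at this position can move the number beyond the scatter.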